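The source may hold more compounds than are shown below. What is called first, only, known or untested is meant among the compounds shown, and "the series" means these compounds.

Compound 1 `CCC(=O)N1N=C(c2ccc(C)cc2)CC1c1cn(-c2ccccc2)nc1-c1ccc(Cl)c(Cl)c1`: 70.3%
Compound 2 `CCC(=O)N1N=C(c2ccc(F)cc2)CC1c1cn(-c2ccccc2)nc1-c1ccc(Cl)c(Cl)c1`: 75.6%
Compound 3 `O=[N+]([O-])c1ccc(N2N=C(c3ccc(Cl)cc3)CC2c2cn(-c3ccccc3)nc2-c2ccc(Cl)c(Cl)c2)cc1`: 69.5%

In a functional assay on the whole organism (strain Wistar) for inhibition, with Rattus norvegicus as the target, read by paw edema, with stated times of 30 min and 120 min, at a dose of 50 mg/kg by the oral route (on this read-out lower numbers stand for less inhibition and higher numbers for more inhibition at the one dose given (going by the name of the read-out)), compound 3 gives 69.5%, the lowest of the three numbers shown, but its nearest neighbour is compound 1, which gives 70.3%, and the gap to compound 2, which gives 75.6%, is also within the scatter; so the three measured compounds cannot be told apart on this read-out.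

Compound 4 `CCC(=O)N1N=C(c2ccc(Cl)cc2)CC1c1cn(-c2ccccc2)nc1-c1ccc(Cl)c(Cl)c1` has not been measured. It differs from compound 3 by propanoyl in place of 4-nitrophenyl on an amine nitrogen in a ring. Among the measured compounds shown here, compounds 1 and 2 already carry this propanoyl group on the shared core, and the one measured step, a number 5.3 percentage points higher from compound 1 to compound 2 (within the scatter), shows that a change on the aromatic ring held two ring bonds away left the read-out within the scatter. For the measured compounds named here, no measured step alters the group on the ring nitrogen itself, so the change from compound 3 to compound 4 has no direct precedent here. The values of compounds 1, 2 and 3 all sit close together, and a step of about a number 2.5 percentage points higher from compound 3 to compound 4 (within the scatter) is expected, which is no movement beyond the scatter. Compound 4 is therefore estimated to give 72%, in a range from 62% to 82%.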

Compound 4, a percentage reported as inhibition, in the whole organism at one dose (the size of the read-out at that dose, not a potency): 68.8%
Beside the measured number, compound 4's estimate is 3.2 percentage points above it, and the stated range covers the measured number.
By their numbers in this assay, from the lowest: compounds 4, 3, 1 and 2 (each within the scatter of the next).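

In this assay, among the compounds shown here, propanoyl in place of 4-nitrophenyl on the amine nitrogen in a ring gives a number 0.7 percentage points lower from compound 3 to compound 4 (within the scatter), so the first change at this position, which no earlier step had touched, leaves the read-out within the scatter. With propanoyl held in place, chloro in place of fluoro on an aromatic carbon gives a number 6.8 percentage points lower from compound 2 to compound 4 (within the scatter) and chloro in place of methyl gives a number 1.5 percentage points lower from compound 1 to compound 4 (within the scatter), so the chloro, fluoro and methyl compounds cannot be told apart. Nothing available here offers an explanation for these results.

On these data alone, whether a longer chain, a carboxylic acid or an amine on that ring nitrogen, or a methoxy group on that aromatic carbon, would shift the read-out beyond the scatter remains open. With only one dose, any difference in potency among these compounds also remains open.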